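Cyano in place of methyl: compound 3 to compound 4

The compounds below may be only part of what the source reports. "The series", "measured", "known", "first", "only" and "open" are said of these compounds alone.

Measured in a functional assay on DLD-1 cells (Homo sapiens) for cytotoxicity, with a stated time of 48 h; a lower number here means a stronger inhibitor, a higher number a weaker inhibitor:
- compound 1 `CCOc1ccc2oc(/C=C/[S+](C)[O-])cc(=O)c2c1` gives 4900 nM in this series
- compound 2 `CC(C)CC(=O)Oc1ccc2oc(/C=C/[S+](C)[O-])cc(=O)c2c1` gives 6100 nM in this series
- compound 3 `Cc1ccc2oc(/C=C/[S+](C)[O-])cc(=O)c2c1` gives 7000 nM in this series

Compound 3 at 7000 nM lies within the scatter of both other compounds, so the three values form one flat group. Compound 4 `C[S+]([O-])/C=C/c1cc(=O)c2cc(C#N)ccc2o1` carries cyano in place of methyl on an aromatic carbon and has not been measured. The measured steps at this carbon are a 1.4-fold higher number from compound 1 to compound 3 (0.15 log units; within the scatter) and a 1.1-fold higher number from compound 2 to compound 3 (0.06 log units; within the scatter) and each lies within the scatter, as does a 1.2-fold higher number from compound 1 to compound 2 (0.10 log units; within the scatter) on the oxygen. Among the measured compounds shown here, no cyano compound has been measured, so nothing beyond the scatter is expected in this assay for this change. The expected step is a 1.2-fold lower number from compound 3 to compound 4 (0.07 log units; within the scatter) and it stays within the scatter. For compound 4 the estimate is 6000 nM with an expected range from 2500 nM to 14000 nM in this read-out.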

Compound 4, half-maximal inhibitory concentration: > 10000 nM
Compound 4: only a limit was reported (the forecaster's own chance of this, stated with the estimate: 5%); middle value at least 1.6-fold (0.22 log units) from the limit.
By their numbers in this assay, from the lowest: compounds 1, 2 and 3 (each within the scatter of the next). At a limit, above all of these: compound 4.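

In this assay compound 4 has only a limit of the assay, not a number: the limit of > 10000 nM in this assay, at which 1 of the 4 values shown sits. Cyano is thus the only group shown on this aromatic carbon that ends at a limit, and the steps are an at least 1.4-fold higher number from compound 3 to compound 4 (0.15 log units; that floor lies within the scatter), an at least 1.6-fold higher number from compound 2 to compound 4 (0.21 log units; that floor lies within the scatter) and an at least 2.0-fold higher number from compound 1 to compound 4 (0.30 log units; that floor lies within the scatter). Since each floor stays within the scatter, this change is not yet separated from the flat group of compound 1, compound 2 and compound 3.

From the compounds shown here alone, the true value of compound 4 remains open. So does whether an amine or a carboxylic acid on this carbon would move the number beyond the scatter.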